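A few compounds are considered here, and "the series" means these few. Any claim that something is new, unique, unknown or untested is made for them only; others in the source may bear on it.

Measured in a functional assay on A549 cells (Homo sapiens) for cytotoxicity, read by MTT assay, with a stated time of 48 h; a higher number here means a weaker inhibitor, a lower number a stronger inhibitor:
- Compound 1 `COc1ccc(/C=C/c2cc(OC)c(OC)c(OC)c2-c2ccccc2)cc1`: 36000 nM
- Compound 2 `COc1ccc(/C=C/c2cc(OC)c(OC)c(OC)c2-c2ccc(Cl)cc2)cc1`: 30000 nM
- Compound 3 `COc1ccc(/C=C/c2cc(OC)c(OC)c(OC)c2-c2ccc(OC)c(OC)c2)cc1`: 28000 nM

Compound 1 stands level with the other two compounds. Its comparisons show a 1.2-fold lower number from compound 1 to compound 2 (0.08 log units; within the scatter) and a 1.3-fold lower number from compound 1 to compound 3 (0.11 log units; within the scatter), so the three values cannot be put in a meaningful order.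

The next compound to be tested is compound 4 `COc1cc(/C=C/c2ccc(C)cc2)c(-c2ccccc2)c(OC)c1OC`. It keeps the core of compound 1 and differs in one place, with methyl in place of methoxy on an aromatic carbon, para to a large group. This turns 4-methoxyphenyl into 4-methylphenyl: methyl in place of methoxy on an aromatic carbon.

Within the data shown here, no measured step touches this group, so the evidence is only indirect. All three measured steps alter the phenyl group of compound 1 instead. Besides the two steps above, the comparison of the substituted compounds gives a 1.1-fold lower number from compound 2 to compound 3 (0.03 log units; within the scatter). Each of these changes left the number within the scatter in this assay. On that limited evidence, no shift beyond the scatter is expected here, and no direction can be favoured. The expected result is a 1.2-fold lower number from compound 1 to compound 4 (0.08 log units; within the scatter). For compound 4 the estimated value is 30000 nM, with an expected range of 14000 nM to 65000 nM.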

Compound 4, half-maximal inhibitory concentration: 54000 nM
For compound 4 the middle estimate is 1.8-fold (0.26 log units) below the measured one; low and high end bracket the measured number.
By their numbers in this assay, from the lowest: compounds 3, 2, 1 and 4 (each within the scatter of the next).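

Replacing the methoxy of the 4-methoxyphenyl group with methyl is the first change shown at this position, and in this assay it gives a 1.5-fold higher number from compound 1 to compound 4 (0.18 log units; within the scatter). Until now every comparison concerned the phenyl group on the other side of the molecule, so this step extends the picture: a change at this second site also leaves the number within the scatter, even though the oxygen and the hydrogen-bond acceptor of the methoxy are gone. No other data shown here bear on this result, so it remains a single reading of one swap at this position.

The compounds shown leave open whether this position would respond to a group less like methoxy, such as an amine, a carboxylic acid or a longer chain like butoxy, any of which would test it far more severely than methyl does. From the compounds shown here alone, it also remains open whether methyl in place of methoxy would read the same when combined with the 4-chlorophenyl group of compound 2 or the 3,4-dimethoxyphenyl group of compound 3.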